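The compounds below may be only part of what the source reports. "The series", "measured", "known", "first", "only" and "open" are said of these compounds alone.

Measured compounds and their values in an assay on membranes from Cortex for displacement of a labelled ligand from Sigma non-opioid intracellular receptor 1 (Cavia porcellus), read by scintillation counting, with a stated time of 120 min; a lower number here means a stronger inhibitor, a higher number a weaker inhibitor:

compound 1 `Fc1ccc(C(SCCNC2CCN(Cc3ccccc3)CC2)c2ccc(F)cc2)cc1` gives 3.81 nM
compound 2 `Fc1ccc(C(SCCNC2CCN(Cc3ccc(C(F)(F)F)cc3)CC2)c2ccc(F)cc2)cc1` gives 186 nM
compound 3 `Fc1ccc(C(SCCNC2CCN(Cc3cc4ccccc4o3)CC2)c2ccc(F)cc2)cc1` gives 205 nM

Compound 1 has the lowest number of the three, and both others sit clearly apart from it: the step of a 49-fold higher number from compound 1 to compound 2 (1.69 log units; beyond the scatter) and the step of a 54-fold higher number from compound 1 to compound 3 (1.73 log units; beyond the scatter) are each beyond the scatter. Between compound 2 and compound 3 the step of a 1.1-fold higher number from compound 2 to compound 3 (0.04 log units; within the scatter) lies within the scatter, so no order between those two can be drawn.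

Compound 4 `O=C(c1ccc(F)cc1F)N1CCC(NCCSC(c2ccc(F)cc2)c2ccc(F)cc2)CC1` has not yet been measured. It differs from compound 1 in one place: (2,4-difluorophenyl)carbonyl in place of benzyl on an amine nitrogen in a ring. The two measured steps bear on this. Each of them also changed the group that sits on the amine nitrogen in a ring of the shared core, and each cost a large amount, as the step of a 49-fold higher number from compound 1 to compound 2 (1.69 log units; beyond the scatter) and the step of a 54-fold higher number from compound 1 to compound 3 (1.73 log units; beyond the scatter) show. Compound 4 makes a change at the same place, and a larger one, since the benzyl leaves entirely and a carbonyl-linked ring enters. A step of comparable size, toward a higher number, is therefore expected, as a 52-fold higher number from compound 1 to compound 4 (1.72 log units; beyond the scatter). Compound 4 is estimated to give 200 nM, within a range from 30 nM to 2000 nM.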

Compound 4, inhibition constant: 20.6 nM
Beside the measured number, compound 4's estimate is 9.7-fold (0.99 log units) above it, and the stated range ends above it.
By their numbers in this assay, from the lowest: compound 1; then compound 4; then compounds 2 and 3 (each within the scatter of the next).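

In this assay, among these compounds, the amine nitrogen in a ring still tolerates a group attached through a carbonyl instead of the benzyl of compound 1: a 5.4-fold higher number from compound 1 to compound 4 (0.73 log units; beyond the scatter) is a real loss but only a modest one, so this benzyl is not the only workable group at this place. The two earlier changes here might have suggested that any replacement costs a large amount, but the new compound stands clearly apart from both, as shown by a 10-fold lower number from compound 3 to compound 4 (1.00 log units; beyond the scatter) and by a 9.0-fold lower number from compound 2 to compound 4 (0.96 log units; beyond the scatter), even though (2,4-difluorophenyl)carbonyl has more heavy atoms than benzyl and adds a hydrogen-bond acceptor. Nothing measured here explains these differences.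

This change replaces the link to the nitrogen and adds two fluorines to the aromatic ring at once, so the compounds shown leave open which of the two accounts for the result; a plain benzoyl group and a difluorobenzyl group would separate them. Also open, as far as these compounds go, is how a longer chain between the nitrogen and the aromatic ring would compare with the carbonyl link of compound 4.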